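From Compound 2 to Compound 4: a Change on Sulfur

The source may report more compounds than this note shows. Statements on the series, on what has been measured and on what is new or still open speak of the compounds shown alone.

Three compounds sharing one core were measured in an assay on isolated protein for inhibition of Retinaldehyde dehydrogenase 3 (Homo sapiens); on this read-out lower numbers stand for stronger inhibition and higher numbers for weaker inhibition. Compound 1 `Cn1ncc2c(=O)n(-c3ccccc3)c(COc3cccc(F)c3)nc21` gives 780 nM, compound 2 `Cn1ncc2c(=O)n(-c3ccccc3)c(SC(C)(C)c3ccccc3)nc21` gives 1390 nM, and compound 3 `Cn1ncc2c(=O)n(-c3ccccc3)c(CCc3cccc(F)c3)nc21` gives 2500 nM. Compound 2 holds the second highest of the three numbers, and its value lies within the scatter of both compound 1 and compound 3. Among the compounds with values here, the one measured step, a 3.2-fold higher number from compound 1 to compound 3 (0.51 log units; beyond the scatter), concerns a saturated chain carbon and does not touch the sulfur. Compound 4 `CC(Sc1nc2c(cnn2C)c(=O)n1-c1ccccc1)c1cccnc1` differs from compound 2 by 1-(pyridin-3-yl)ethyl in place of 1-methyl-1-phenylethyl on a sulfur. Within the data shown here, no measured step bears on this change, so in this assay no step beyond the scatter is expected, a 1.0-fold higher number from compound 2 to compound 4 (0.00 log units; within the scatter). Compound 4 is therefore estimated at 1400 nM, within a range from 450 nM to 4500 nM.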

Compound 4, half-maximal inhibitory concentration: 95 nM
Beside the measured number, compound 4's estimate is 15-fold (1.17 log units) above it; the whole stated range lies above it.
By their numbers in this assay, from the lowest: compound 4; then compounds 1, 2 and 3 (each within the scatter of the next, the first and the last beyond it).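

In this assay, the group on the sulfur turns out to be a place where one change moves the number well beyond the scatter: 1-(pyridin-3-yl)ethyl in place of 1-methyl-1-phenylethyl gives a 15-fold lower number from compound 2 to compound 4 (1.17 log units; beyond the scatter). Within the data shown here, this is the first measured step at the sulfur, and the entering group brings a ring nitrogen with one hydrogen-bond acceptor, where the leaving group has none. Nothing at hand gives a reason for this step.

The change swaps the ring and removes a methyl together, and the compounds shown do not separate the two. As far as these compounds go, how a plain 1-phenylethyl group or a 1-(pyridin-2-yl)ethyl group on the sulfur would read remains open.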